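The source may hold more compounds than are shown below. What is called first, only, known or untested is meant among the compounds shown, and "the series" means these compounds.

Measured in a functional assay on BaF3 cells (Mus musculus) for antiproliferative activity, read by CCK-8 assay and cell counting, with a stated time of 76 h; on this read-out lower numbers stand for stronger inhibition and higher numbers for weaker inhibition:
compound 1 `COc1cc2nccc(Oc3ccc(Nc4nn(C)cc4C(=O)NC45CCC(CC4)CC5)cc3)c2cc1C(N)=O`: > 10000 nM
compound 2 `COc1cc2nccc(Oc3ccc(Nc4nn(C)cc4C(=O)N4CCCCC4)cc3)c2cc1C(N)=O`: 5650 nM
compound 3 `COc1cc2nccc(Oc3ccc(Nc4nn(C)cc4C(=O)N4CCCC5CCCCC54)cc3)c2cc1C(N)=O`: 4330 nM

The value for compound 1, > 10000 nM, is a limit of the assay. Compound 3 stands within the scatter of compound 2 (a 1.3-fold lower number from compound 2 to compound 3 (0.12 log units; within the scatter)) and apart from that limit (an at least 2.3-fold lower number from compound 1 to compound 3 (0.36 log units; beyond the scatter)). Compound 4 `COc1cc2nccc(Oc3ccc(Nc4nn(C)cc4C(=O)Nc4ccccc4F)cc3)c2cc1C(N)=O` differs from compound 3 by one change: a group of 8 heavy atoms (6 carbon, 1 nitrogen, 1 fluorine; one six-membered aromatic ring of carbon only) in place of a group of 10 heavy atoms (9 carbon, 1 nitrogen; one six-membered non-aromatic ring of carbon only, one six-membered non-aromatic ring with 1 hetero atom), on a carbonyl carbon. The measured steps, these two and an at least 1.7-fold lower number from compound 1 to compound 2 (0.24 log units; that floor lies within the scatter), exchange saturated groups only, so they bound the new step loosely. Compound 3, at 4330 nM, leaves little room for a higher number, so a lower number is expected, with its size uncertain. The expected step is a 5.4-fold lower number from compound 3 to compound 4 (0.73 log units; beyond the scatter). For compound 4 the estimate is 800 nM, with an expected range of 50 nM to 10000 nM.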

Compound 4, half-maximal inhibitory concentration: 1710 nM
The estimate for compound 4 lay 2.1-fold (0.33 log units) below the measured number, within the range that was stated.
By their numbers in this assay, from the lowest: compound 4; then compounds 3 and 2 (each within the scatter of the next). At a limit, above all of these: compound 1.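

In this assay, (2-fluorophenyl)amino on the carbonyl carbon brings the first aromatic ring and the first amide hydrogen among these groups, and it stands apart from both saturated ring amides (a 2.5-fold lower number from compound 3 to compound 4 (0.40 log units; beyond the scatter); a 3.3-fold lower number from compound 2 to compound 4 (0.52 log units; beyond the scatter)). Compounds 2 and 3 remain within the scatter of each other, so the larger saturated ring group does not separate from piperidin-1-yl. The value for compound 1 is a limit, so its step gives only a floor (an at least 5.8-fold lower number from compound 1 to compound 4 (0.76 log units; beyond the scatter)): the limit of > 10000 nM in this assay, at which 1 of the 4 values shown sits.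

The aromatic ring, the fluorine and the amide hydrogen all enter together in compound 4, and the compounds shown do not separate them. As far as these compounds go, how an unsubstituted phenylamino or a pyridinylamino would stand remains open.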